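Aminothiazole ketones: replacing the aryl with amino

A few compounds are considered here, and "the series" means these few. Any claim that something is new, unique, unknown or untested is made for them only; others in the source may bear on it.

Measured so far in a functional assay on GC-2 cells (Mus musculus) for cytotoxicity, read by MTT assay, with a stated time of 72 h; a higher number here means a weaker inhibitor, a lower number a stronger inhibitor:
- compound 1 `Nc1nc(NC2CCCCC2)sc1C(=O)c1ccccc1`: 8200 nM
- compound 2 `Nc1nc(Nc2ccccc2)sc1C(=O)c1ccc(F)cc1`: 17000 nM
- compound 3 `Nc1nc(Nc2ccccc2)sc1C(=O)c1cccc(F)c1`: 4100 nM

Compound 2 gives the highest number of the three, with compound 1 nearest and compound 3 furthest, both below it and both gaps beyond the scatter. For the measured compounds named here, the one single-point step available, a 4.1-fold lower number from compound 2 to compound 3 (0.62 log units; beyond the scatter), moves the fluorine within the ring on the carbonyl carbon and is modest in size.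

Compound 4 `NC(=O)c1sc(Nc2ccccc2)nc1N` differs from compound 2 as follows: amino in place of 4-fluorophenyl on a carbonyl carbon. Going by the values given here, no measured step bears directly on this change: the step from compound 2 to compound 3 keeps the six-membered aromatic ring in place and only relocates the fluorine, whereas here the whole ring leaves and a single nitrogen enters. The step from compound 2 to compound 3 therefore says only that alterations at this carbonyl carbon are felt in this assay, not in which direction a far larger removal will go. With all three measured compounds carrying an aromatic ring on the carbonyl carbon, its loss is expected to weaken inhibition, so a step upward in this assay is expected, a 2.1-fold higher number from compound 2 to compound 4 (0.31 log units; beyond the scatter). For compound 4 the expected value in this assay is 35000 nM, within 9000 nM to 130000 nM, with a real chance that only a limit is reported.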

Compound 4, half-maximal inhibitory concentration: > 60000 nM
Compound 4 gave a limit, no number; the forecaster's own chance of this, stated with the estimate: 30%; middle value at least 1.7-fold (0.23 log units) away from the limit.
By their numbers in this assay, from the lowest: compounds 3 and 1 (each within the scatter of the next); then compound 2. At a limit, above all of these: compound 4.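

Amino in place of 4-fluorophenyl on a carbonyl carbon removes the whole aromatic ring instead of relocating its fluorine, and in this assay this gives an at least 3.5-fold higher number from compound 2 to compound 4 (0.54 log units; beyond the scatter). The same exchange starting from the 3-fluorophenyl group gives an at least 14-fold higher number from compound 3 to compound 4 (1.16 log units; beyond the scatter), so among these three compounds the direction holds for both fluorine placements, with no exception: the numbers are lower with the ring present, in compound 2 and compound 3, and the amide compound 4 has no measured number. Compound 4 stands at a limit of the assay, so both steps give only a minimum size for the change: the limit of > 60000 nM in this assay, at which 1 of the 4 values shown sits.

The compounds shown leave open how much of the step goes with the loss of the aromatic ring and how much with the entry of the amino, since the two happen together in this one change. A methyl group, a cyclohexyl ring or a dimethylamino group on the same carbonyl carbon would help separate those two parts, and would show whether an aromatic ring is needed there or any larger carbon group will do.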